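The source may hold more compounds than are shown below. What is called first, only, known or untested is meant among the compounds shown, and "the series" means these compounds.

Measured compounds:
compound 1, `O=C1C(c2ccccc2)=C(O)CC1Cc1cccc2c1CCC(NS(=O)(=O)c1ccc(Cl)cc1)C2`, gives 3.9 nM
compound 2, `O=C1C(c2ccc(F)cc2)=C(O)CC1Cc1cccc2c1CCC(NS(=O)(=O)c1ccc(Cl)cc1)C2`, gives 6.5 nM

Both compounds were tested in a functional assay on HEK293-A cells for antagonist activity at thromboxane A2 receptor (Homo sapiens), read by HTRF and inositol phosphate accumulation, with a stated time of 60 min; on this read-out lower numbers stand for stronger inhibition and higher numbers for weaker inhibition. Compound 2 stands alongside compound 1 on these numbers: the step of a 1.7-fold higher number from compound 1 to compound 2 (0.22 log units; within the scatter) lies within the scatter, so the two compounds cannot be separated on this read-out. They share the same core and differ only in a single substituent on one aromatic ring.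

Compound 3, `COc1ccc(C2=C(O)CC(Cc3cccc4c3CCC(NS(=O)(=O)c3ccc(Cl)cc3)C4)C2=O)cc1`, continues at that same position. The change from compound 2 is methoxy in place of fluoro on an aromatic carbon. Within the data shown here, only one measured step bears on it: the earlier exchange of hydrogen for fluoro at this aromatic carbon, from compound 1 to compound 2, which gave a 1.7-fold higher number from compound 1 to compound 2 (0.22 log units; within the scatter). That single step is small, so there is no measured ground to expect a large shift when methoxy replaces fluoro. Compound 3 is therefore expected to show a step of a 1.4-fold higher number from compound 2 to compound 3 (0.14 log units; within the scatter), a number that need not go beyond the scatter. Compound 3 is estimated at 9 nM, with a range from 3 nM to 30 nM.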

Compound 3, half-maximal inhibitory concentration: 0.052 nM
Beside the measured number, compound 3's estimate is 170-fold (2.24 log units) above it, outside the stated range (below it).
By their numbers in this assay, from the lowest: compound 3; then compounds 1 and 2 (each within the scatter of the next).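

In this assay, the step of a 130-fold lower number from compound 2 to compound 3 (2.10 log units; beyond the scatter) and the step of a 75-fold lower number from compound 1 to compound 3 (1.88 log units; beyond the scatter) show that this carbon of the aromatic ring, para to a large group, can strongly change the read-out. The exchange of hydrogen for fluoro at this carbon stayed within the scatter, so the earlier pair gave no sign of such sensitivity; methoxy now separates clearly from both hydrogen and fluoro on the same shared core, and the 4-methoxyphenyl compound has the lowest number of the three. No measurement at hand explains why methoxy has this effect.

The compounds shown leave open whether this large drop belongs to methoxy alone or would also appear with a hydroxyl, an ethoxy or a dimethylamino group on the same carbon. They also leave open whether a longer chain ending in a carboxylic acid would keep the number this low, which would show how much room this position allows.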